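Taking one hydroxy group off compound 1

The source may hold more compounds than are shown below. What is called first, only, known or untested is meant among the compounds shown, and "the series" means these compounds.

Measured so far in a toxicity assay on cells (Erythrocyte, Mus musculus) for activation, read by spectrophotometry and hemolysis, with a stated time of 30 min; on this read-out lower numbers stand for an effect already at smaller amounts and higher numbers for an effect only at larger amounts of compound:
- compound 1 `Oc1ccc(/C=N/Nc2nc3ccccc3s2)cc1O` gives > 200 ug/mL
- compound 2 `O=C(O)c1ccccc1/C=N/Nc1nc2ccccc2s1` gives > 200 ug/mL
- compound 3 `Cc1ccc(/C=N/Nc2nc3ccccc3s2)c(C)c1` gives > 200 ug/mL

Compound 1 stands at > 200 ug/mL in this assay, which is a limit of the assay and not a number. Compound 2 and compound 3 also give only a limit, so the series reads alike, with the limit of > 200 ug/mL in this assay, at which 3 of the 3 values shown sit, as the whole picture. For the measured compounds named here, no two measured compounds differ in just one place, so no measured step can guide the next one.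

Compound 4 `Oc1ccc(/C=N/Nc2nc3ccccc3s2)cc1` is compound 1 with a single change (hydrogen in place of hydroxy on an aromatic carbon): hydrogen in place of hydroxy on an aromatic carbon, ortho to a hydroxy group and meta to a large group. With compound 1 at the limit of > 200 ug/mL as the only anchor, no change beyond the scatter is expected in this assay, in either direction. The estimated step (a step that the limit leaves unreadable from compound 1 to compound 4) therefore stays small. Compound 4 is estimated at 250 ug/mL (range 130 ug/mL to 500 ug/mL).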

Compound 4, half-maximal effective concentration: > 200 ug/mL
Compound 4: only a limit was reported; the forecaster's own chance of this, stated with the estimate: 90%; the middle value is on the limit's open side.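

For the compounds shown here, compound 1 and compound 4 each give only a limit of the assay in this assay, not a number, so no step between them can be read. The compounds shown leave open at what concentration any of them would show an effect in this assay, and whether losing that hydroxy group changes it.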